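The source may report more compounds than this note shows. Statements on the series, on what has been measured and on what is new or still open speak of the compounds shown alone.

Compound 1 `CCc1ccccc1C(=O)Nc1c[nH]nc1C(=O)N[C@H]1CC[C@H](OC)CC1`: 3400 nM
Compound 2 `COc1ccccc1C(=O)Nc1c[nH]nc1C(=O)N[C@H]1CC[C@H](OC)CC1`: 1500 nM

Going by the values given here, in an ADME assay on MRC5 cells (Homo sapiens) for inhibition, with a stated time of 72 h (a higher number here means that more compound is needed for the effect, a lower number that less compound is needed), compound 2 gives 1500 nM, the lower of the two numbers so far. Compound 3 `CO[C@H]1CC[C@H](NC(=O)c2n[nH]cc2NC(=O)c2cc3ccccc3o2)CC1` has not yet been measured. It carries 1-benzofuran-2-yl in place of 2-methoxyphenyl on a carbonyl carbon. Among the compounds with values here, only one measured step bears on this, and it is modest: a 2.3-fold lower number from compound 1 to compound 2 (0.36 log units; beyond the scatter). That step swapped ethyl for methoxy on an aromatic carbon, not a whole group, so it gives no direction for this change. The expected step is no change at the digits printed from compound 2 to compound 3 (within the scatter), with none beyond the scatter foreseen in this assay. The estimate for compound 3 is 1500 nM, with an expected range from 400 nM to 5000 nM.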

Compound 3, half-maximal effective concentration: 800 nM
For compound 3 the middle estimate is 1.9-fold (0.27 log units) above the measured one, within the range that was stated.
By their numbers in this assay, from the lowest: compounds 3 and 2 (each within the scatter of the next); then compound 1.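

The earlier step changed only a small group on an aromatic carbon, whereas this change replaces the whole group on the carbonyl carbon. In this assay, a 1.9-fold lower number from compound 2 to compound 3 (0.27 log units; within the scatter) shows that 1-benzofuran-2-yl, with its added five-membered aromatic ring, and 2-methoxyphenyl cannot be told apart here, while a 4.3-fold lower number from compound 1 to compound 3 (0.63 log units; beyond the scatter) separates 1-benzofuran-2-yl from 2-ethylphenyl. No measurement of any property accounts for these steps. Still open, going by these compounds, is whether an amine or a carboxylic acid on the 1-benzofuran-2-yl group, or a plain alkyl chain in its place, would move the number beyond the scatter.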